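This account rests on a few compounds, and the source may have more. Where it says the series, first, only, none or still open, it means among the compounds named here.

Compound 1, `Cc1cccc(Cn2c(N)nc3cc(Cl)c(Cl)cc32)c1`, gives in a functional assay on KB cells (Homo sapiens) for inhibition (a lower number here means a stronger inhibitor, a higher number a weaker inhibitor), a value of 65000 nM. Compound 2, `Nc1nc2cc(Cl)c(Cl)cc2n1Cc1cccc(C(F)(F)F)c1`, gives in this assay a value of 45000 nM. Compound 3, `Cc1ccc(Cn2c(Br)nc3cc(Cl)c(Cl)cc32)cc1`, gives in this assay only a limit, > 100000 nM.

Two of these compounds share one core, and the third differs from it. The difference between the core of compound 1 and the core of compound 3 is not broken down here. Within the first pair the change is trifluoromethyl in place of methyl on an aromatic carbon. That change made a 1.4-fold lower number from compound 1 to compound 2 (0.16 log units; within the scatter), so compound 1 and compound 2 cannot be told apart in this assay.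

Compound 3 stands at the limit of > 100000 nM in this assay, at which 1 of the 3 values shown sits, and for it only that limit is known.

Compound 4, `FC(F)(F)c1ccc(Cn2c(Br)nc3cc(Cl)c(Cl)cc32)cc1`, has not yet been measured in this assay. It carries the same kind of change relative to compound 3 as compound 2 carries relative to compound 1: trifluoromethyl in place of methyl on an aromatic carbon. The two changes are the same in what leaves and what enters, but the surroundings differ: in the pair of compound 1 and compound 2 the group sits meta to a large group, while in the pair of compound 3 and compound 4 it sits para to a large group.

Since the earlier change gave a 1.4-fold lower number from compound 1 to compound 2 (0.16 log units; within the scatter), the step from compound 3 to compound 4 is expected to be small as well, a number no higher from compound 3 to compound 4 (the limit leaves the size open). Compound 4 is therefore expected to sit near the limit of compound 3, with an estimate of 100000 nM and a range from 40000 nM to 300000 nM, and it is likely that only a limit will be reported.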

Compound 4, half-maximal inhibitory concentration: > 100000 nM
Compound 4: no number, only a limit; the forecaster's own chance of this, stated with the estimate: 65%; the middle value lies on the limit itself.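

In this assay compound 4 gives only a limit, > 100000 nM. For the compounds shown here, compound 3 also gives only a limit, > 100000 nM, so no step between compound 3 and compound 4 can be read. The same limit now holds for both compounds: the limit of > 100000 nM in this assay, at which 2 of the 4 values shown sit. The compounds shown leave open whether trifluoromethyl in place of methyl, para to a large group, changes the value at all.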